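The source may hold more compounds than are shown below. What is called first, only, known or untested is meant among the compounds shown, and "the series" means these compounds.

Compounds built on one shared core have so far given closely matched numbers. In a functional assay on MCF7 cells (Homo sapiens) for inhibition, read by MTT assay, with a stated time of 48 h (a higher number here means a weaker inhibitor, a lower number a stronger inhibitor), compound 1 (`CCOC(=O)C1=C(N/N=C(/Br)c2ccccc2)Nc2[nH]nc(C)c2C1c1ccc(N(C)C)cc1`) gives 78400 nM and compound 2 (`CCOC(=O)C1=C(N/C=N/c2ccc([N+](=O)[O-])cc2)Nc2[nH]nc(C)c2C1c1ccc(N(C)C)cc1`) gives 58600 nM. Within the data shown here, compound 2 therefore stands level with compound 1, the only other measured compound, within the scatter.

Compound 3 (`CCOC(=O)C1=C(N/N=C(/C(C)=O)C(=O)OCC)Nc2[nH]nc(C)c2C1c1ccc(N(C)C)cc1`) has yet to be measured in this assay. Its difference from compound 2 is a group of 10 heavy atoms (6 carbon, 1 nitrogen, 3 oxygen; no ring) in place of a group of 11 heavy atoms (7 carbon, 2 nitrogen, 2 oxygen; one six-membered aromatic ring of carbon only), on an amine nitrogen. The entering group has no ring and 3 double bonds outside aromatic rings, whereas the departing group has one six-membered aromatic ring of carbon only.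

Among the measured compounds shown here, one measured step bears on this change: a 1.3-fold lower number from compound 1 to compound 2 (0.13 log units; within the scatter). That exchange also took place on an amine nitrogen, but both of its groups carried a six-membered aromatic ring of carbon only. The data therefore do not show what removing that ring does, and the estimate stays wide.

The expected change is a 1.0-fold higher number from compound 2 to compound 3 (0.01 log units; within the scatter), which means no step beyond the scatter is expected. For compound 3 the estimated value is 60000 nM, with an expected range from 25000 nM to 130000 nM.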

Compound 3, half-maximal inhibitory concentration: > 100000 nM
Compound 3: a limit, no number (the forecaster's own chance of this, stated with the estimate: 10%); middle value at least 1.6-fold (0.22 log units) away from the limit.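

In this assay compound 3 gives a limit of the assay and not a number: the limit of > 100000 nM in this assay, at which 1 of the 3 values shown sits.
Among these compounds, this is the first exchange at this amine nitrogen in which the six-membered aromatic ring of carbon only leaves, and the open-chain group that enters gives an at least 1.7-fold higher number from compound 2 to compound 3 (0.23 log units; that floor lies within the scatter) and also an at least 1.2-fold higher number from compound 1 to compound 3 (0.10 log units; that floor lies within the scatter). Among the compounds shown here, both steps are floors that lie within the scatter, so the result shows no loss beyond the scatter, yet it also gives no sign that the ring can be given up without cost, which the ring-to-ring step among the earlier compounds could not address.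

Going by these compounds, the true size of the step remains unknown, and the loss of the ring cannot be separated from the entry of a group with more double bonds outside aromatic rings and more hydrogen-bond acceptors, since both changes arrive together in compound 3. On these data alone, how a plain alkyl chain, a carboxylic acid or a simple amine would read on this amine nitrogen in this assay also stays open.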